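The source may report more compounds than this note shows. Statements on the series, on what has been measured and on what is new or still open speak of the compounds shown alone.

Series notes. Of the compounds shown here, three have been measured so far in a functional assay on KB cells (Homo sapiens) for cytotoxicity, read by resazurin assay, with a stated time of 3 days; on this read-out higher numbers stand for weaker inhibition and lower numbers for stronger inhibition. Compound 1, `CC(C)(CNC(=O)c1ccccc1)CC1=C(O)C(=O)c2ccccc2C1=O`, gives 15200 nM in this assay. Compound 2, `CC(C)(CNC(=O)c1ccc2ccccc2c1O)CC1=C(O)C(=O)c2ccccc2C1=O`, gives 26900 nM in this assay. Compound 3, `COC1=C(CC(C)(C)CNC(=O)c2ccccc2OC)C(=O)c2ccccc2C1=O`, gives 33200 nM in this assay. Compound 2 sits with its nearest neighbour compound 3, and compound 1 is the furthest of the three from it; both of these gaps lie within the usual scatter, so the three numbers cannot be separated from one another on the present data.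

Compound 4, `COc1c(C(=O)NCC(C)(C)CC2=C(O)C(=O)c3ccccc3C2=O)ccc2ccccc12`, has not yet been measured. Relative to compound 2 the change is methyl in place of hydrogen on an oxygen on an aromatic ring; read one bond further out, hydroxy becomes methoxy. Among the compounds with values here, no measured pair in the set isolates this change. What is known is that compound 1, compound 2 and compound 3, which differ at several places, all fall within the scatter of one another, and compound 3 already carries methoxy groups without moving the number. Compound 4 is therefore expected to show no step beyond the scatter from compound 2 in this assay. The expected step is a 1.0-fold higher number from compound 2 to compound 4 (0.02 log units; within the scatter). For compound 4 the estimate is 28000 nM, with a range from 12000 nM to 65000 nM.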

Compound 4, half-maximal inhibitory concentration: 66900 nM
For compound 4 the middle estimate is 2.4-fold (0.38 log units) below the measured one, and the stated range ends below it.
By their numbers in this assay, from the lowest: compounds 1, 2, 3 and 4 (each within the scatter of the next, the first and the last beyond it).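

In this assay, within the data shown here, methyl in place of hydrogen on an oxygen on an aromatic ring gives a 2.5-fold higher number from compound 2 to compound 4 (0.40 log units; beyond the scatter), the first step that can be read for a single change. Among these compounds, it shows that this place is not indifferent to the change: hydroxy to methoxy here moves the number beyond the scatter, modestly and towards weaker inhibition, whereas the earlier compounds offered no pair differing in one place and so could say nothing about it. No measurement at hand bears on why the step occurs.

Going by these compounds, the reading rests on this one pair, so it remains open whether hydroxy to methoxy would give a similar step at another place on the shared core. Also open, on these data alone, is how the number would respond at this same oxygen to a longer chain such as ethoxy, or to an amine or a carboxylic acid carried on a short chain there, and so whether the step follows the size of the group or its identity.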